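Tert-butyl to trifluoromethyl on the hydroxy-bearing ring

The compounds below may be only part of what the source reports. "The series", "measured", "known", "first", "only" and "open" are said of these compounds alone.

Two compounds carry the shared core. Compound 1 `N#Cc1cc(C(=O)N2CC=CC2)cc(C(F)(F)F)c1O` gives 83% in an assay on isolated protein for inhibition of solute carrier family 22 member 12 (Homo sapiens), tested at 3 uM; on this read-out lower numbers stand for less inhibition and higher numbers for more inhibition at the one concentration tested (going by the name of the read-out). Compound 2 `CC(C)(C)c1cc(C(=O)N2CCCC2)cc(C#N)c1O` gives 84% in this assay, a number within the scatter of that of compound 1, so the two cannot be told apart on this read-out. Compound 3 `N#Cc1cc(C(=O)N2CCCC2)cc(C(F)(F)F)c1O` is not yet measured; it differs from compound 2 by trifluoromethyl in place of tert-butyl on an aromatic carbon. No step between measured compounds is available, and the scatter between compound 1 and compound 2 gives no reason to expect a change beyond it, so the expected step of a number 2 percentage points lower from compound 2 to compound 3 (within the scatter) is small. Compound 3 is estimated at 82%, between 68% and 93%, in this assay.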

Compound 3, a percentage reported as inhibition, at one concentration (the size of the read-out at that concentration, not a potency): 66%
Estimate against measurement, compound 3: 16 percentage points above, outside the stated range (below it).
By their numbers in this assay, from the lowest: compound 3; then compounds 1 and 2 (each within the scatter of the next).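

In this assay trifluoromethyl in place of tert-butyl on this aromatic carbon, ortho to the hydroxy group, is not a neutral exchange: it gives a number 18 percentage points lower from compound 2 to compound 3 (beyond the scatter) on this core. With trifluoromethyl held in place, the five-membered ring on the carbonyl carbon also matters, giving a number 17 percentage points lower from compound 1 to compound 3 (beyond the scatter) from that change alone. Nothing at hand bears on the origin of either step. Open, going by these compounds, is how methyl, chlorine or an amine on this aromatic carbon would read against tert-butyl and trifluoromethyl.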